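This account rests on a few compounds, and the source may have more. Where it says the series, first, only, none or still open, it means among the compounds named here.

In an ADME assay on MT2 cells (Homo sapiens) for cytotoxicity, read by MTT assay (on this read-out lower numbers stand for higher toxicity in this test and higher numbers for lower toxicity in this test), compound 3 `OCc1ccc(Nc2ncc(Cc3c(F)cccc3F)o2)cc1Cl` gives 90000 nM, the higher of the two numbers shown. Compound 2 `OCCc1ccc(Nc2ncc(Cc3c(F)cccc3F)o2)cc1` gives 35000 nM in this assay. Compound 1 `O=c1ncccn1SCCc1ccc(Nc2ncc(Cc3c(F)cccc3F)o2)cc1` reaches only the assay limit of > 100000 nM, which is not a number. Among the compounds with values here, the single measured step, an at least 2.8-fold lower number from compound 1 to compound 2 (0.45 log units; beyond the scatter), changes a group on a saturated chain carbon and leaves the aromatic ring untouched. Compound 4 `OCc1ccc(Nc2ncc(Cc3c(F)cccc3F)o2)cc1` differs from compound 3 by hydrogen in place of chloro on an aromatic carbon. Within the data shown here, no measured step concerns a chloro on an aromatic carbon, so no shift beyond the scatter is expected in this assay. For compound 4 the estimate is therefore 90000 nM, between 40000 nM and 200000 nM. The expected step of no change at the digits printed from compound 3 to compound 4 (within the scatter) may bring the number close to the limit described by the limit of > 100000 nM in this assay, at which 1 of the 3 values shown sits.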

Compound 4, half-maximal cytotoxic concentration: > 100000 nM
Compound 4 was reported as a limit; the forecaster's own chance of this, stated with the estimate: 40%; at least 1.1-fold (0.04 log units) between middle value and limit.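

In this assay compound 4 gives > 100000 nM, which is a limit and not a number. Hydrogen in place of chloro, ortho to a hydroxymethyl group, gives an at least 1.1-fold higher number from compound 3 to compound 4 (0.04 log units; that floor lies within the scatter), so removing the chloro does not lower the number, although the true size of this step stays hidden. Hydroxy in place of hydroxymethyl on the saturated chain carbon bound to an aromatic carbon gives an at least 2.8-fold higher number from compound 2 to compound 4 (0.45 log units; beyond the scatter), so the chain matters more here than the chloro.

Going by these compounds, what a fluoro at the chloro's place or an amine in place of the hydroxy would do remains open. The step between compound 1 and compound 4 cannot be read: the limit of > 100000 nM in this assay, at which 2 of the 4 values shown sit.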